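This account rests on a few compounds, and the source may have more. Where it says the series, first, only, none or still open, it means among the compounds named here.

Measured compounds in a functional assay on CCRF-CEM cells (Homo sapiens) for inhibition, read by cell counting, with a stated time of 3 days; a lower number here means a stronger inhibitor, a higher number a weaker inhibitor:
compound 1 `C=C(Br)C(=O)Nc1cccc(-c2cn3nc(-c4ccccc4)sc3n2)c1`, 960 nM
compound 2 `COc1cccc(-c2nn3cc(-c4cccc(N)c4)nc3s2)c1`, > 250000 nM
compound 3 `COc1cccc(Cc2nn3cc(-c4cccc(N)c4)nc3s2)c1`, 40000 nM

Compound 1 holds the lowest number among the values shown. The nearest measured neighbour is compound 3, whose value in this assay sits well beyond the scatter above that of compound 1. For compound 2 only a limit is reported, namely (the limit of > 250000 nM in this assay, at which 1 of the 3 values shown sits), so it yields no number to compare.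

Compound 4 `C=C(Br)C(=O)Nc1cccc(-c2cn3nc(CCc4ccccc4)sc3n2)c1` differs from compound 1 in one place: phenethyl in place of phenyl on an aromatic carbon of the shared core. Among the compounds with values here, no measured pair shows this particular exchange, so no counted step is available to lean on; the bromoacrylamide of compound 1 is kept unchanged in compound 4.

The expectation for compound 4 is a small loss, with the step of a 2.1-fold higher number from compound 1 to compound 4 (0.32 log units; beyond the scatter) expected to stay close to the scatter. The estimate for compound 4 in this assay is 2000 nM, expected to fall between 500 nM and 8000 nM.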

Compound 4, half-maximal inhibitory concentration: 4200 nM
Compound 4: the middle estimate sits 2.1-fold (0.32 log units) below what was measured, and the stated range covers the measured number.
By their numbers in this assay, from the lowest: compound 1; then compound 4; then compound 3. At a limit, above all of these: compound 2.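

In this assay, within the data shown here, phenethyl in place of phenyl on an aromatic carbon of the shared core gives a 4.4-fold higher number from compound 1 to compound 4 (0.64 log units; beyond the scatter), a modest loss and the first measured reading of this position. The position, on the five-membered aromatic ring with 2 nitrogen and 1 sulfur, accepts a chain between the core and the six-membered aromatic ring at this modest cost, with the bromoacrylamide unchanged and the ring itself retained in both compounds. No measured property available here bears on this step, so it stands without an explanation.

On these data alone, whether a longer chain, an amine or a carboxylic acid at this position would extend or reverse the loss remains open. The step also rests on a single pair, so whether the exchange reads the same without the bromoacrylamide is unsettled.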